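This account rests on a few compounds, and the source may have more. Where it says the series, first, only, none or still open, it means among the compounds named here.

Compound 1 `COc1cccc(N2C(=O)COc3ccc(-c4cnc(Cl)c(NS(=O)(=O)c5ccc(F)cc5)c4)cc32)c1` was examined in a functional assay on HCT-116 cells (Homo sapiens) for antiproliferative activity, read by MTT assay, with a stated time of 72 h; on this read-out lower numbers stand for stronger inhibition and higher numbers for weaker inhibition. Compound 1 returned only a limit there, > 40000 nM, so its standing among the numbers shown is open: it rests at the limit of > 40000 nM in this assay, at which 1 of the 2 values shown sits. A second compound, compound 2 `CC(C)N1C(=O)COc2ccc(-c3cccc(NS(=O)(=O)c4ccc(F)cc4)c3)cc21`, gave 22600 nM in this assay. Compound 3 `COc1ccc(N2C(=O)COc3ccc(-c4cnc(Cl)c(NS(=O)(=O)c5ccc(F)cc5)c4)cc32)cc1` differs from compound 1 by 4-methoxyphenyl in place of 3-methoxyphenyl on an amide-type nitrogen in a ring. Among the measured compounds shown here, no measured step between two compounds covers this change, so the shift in this assay is expected to be small, of no clear direction, and within the scatter. Compound 3 is therefore expected to give 45000 nM, between 15000 nM and 120000 nM. The expected step is a step that the limit leaves unreadable from compound 1 to compound 3.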

Compound 3, half-maximal inhibitory concentration: 30100 nM
Compound 3: the middle estimate sits 1.5-fold (0.17 log units) above what was measured; the measured number falls inside the stated range.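

Compound 1 returns only a limit in this assay, > 40000 nM. With 4-methoxyphenyl in place of 3-methoxyphenyl on the amide-type nitrogen in a ring, the change reads as an at least 1.3-fold lower number from compound 1 to compound 3 (0.12 log units; that floor lies within the scatter), so moving the methoxy group gives no firm shift, although a larger one is not excluded. The true size of this step stays unread because one of its ends is a limit: the limit of > 40000 nM in this assay, at which 1 of the 3 values shown sits.

The compounds shown leave open whether an amine or a carboxylic acid on this phenyl ring, or a longer chain on the same nitrogen, would move the number in this assay.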